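A Third Configuration at the Cytotoxicity Limit

The compounds below may be only part of what the source reports. "The series", "measured", "known", "first", "only" and "open" are said of these compounds alone.

In a functional assay on K562 cells (Homo sapiens) for cytotoxicity, read by MTT assay, with a stated time of 48 h (on this read-out lower numbers stand for stronger inhibition and higher numbers for weaker inhibition), compound 1 `COc1cc([C@H]2C[C@@]2(CO)C(=O)Nc2ccccc2)cc(OC)c1OC` gives > 100000 nM, which is a limit of the assay and not a number. Compound 2 `COc1cc([C@H]2C[C@]2(CO)C(=O)Nc2ccccc2)cc(OC)c1OC` gives > 100000 nM, also a limit and not a number, so compound 2 has no readable potency here.

Compound 3 `COc1cc([C@@H]2C[C@]2(CO)C(=O)Nc2ccccc2)cc(OC)c1OC` differs from compound 2 in one place: the two compounds have the same atoms and bonds and differ only in configuration as drawn: 1 of 2 stereo elements differ; a stereocentre at a saturated ring carbon is drawn R in compound 2 and S in compound 3. No atom or bond changes, only the configuration as drawn.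

One measured step is of the same kind: a step that the two limits leave unreadable from compound 1 to compound 2. The evidence from it is thin, consisting of the limit of > 100000 nM in this assay, at which 2 of the 2 values shown sit, and of the fact that compounds 1 and 2 differ only in the configuration as drawn. This pair shows that a change of configuration left both compounds at the limit, but it cannot give the size of any effect.

With compound 2 at its limit of > 100000 nM, no clear step in either direction is expected in this assay, though a readable value cannot be ruled out. The expected change is a number no higher from compound 2 to compound 3 (the limit leaves the size open). Compound 3 is estimated at 100000 nM, with an expected range from 30000 nM to 200000 nM, and the assay will most likely report only a limit again.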

Compound 3, half-maximal inhibitory concentration: > 100000 nM
Compound 3 gave a limit, no number (the forecaster's own chance of this, stated with the estimate: 80%); the middle value sits exactly at the limit.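

In this assay compound 3 gives > 100000 nM, which is a limit and not a number. Among the compounds shown here, compounds 1, 2 and 3 all stop at such a limit, so no step among them can be read. The compounds shown leave open whether configuration changes potency at all, and whether any form of this shared core reaches a readable value in this assay.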